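This account rests on a few compounds, and the source may have more. Where it says the series, first, only, none or still open, it means among the compounds named here.

Of the compounds shown here, three sharing one core have been tested in a functional assay on SF-539 cells (Homo sapiens) for inhibition, read by sulforhodamine B assay, with a stated time of 48 h, tested at 10 uM; on this read-out higher numbers stand for more inhibition at the one concentration tested (going by the name of the read-out) and lower numbers for less inhibition. Compound 1 `Clc1ccc(-c2cn3ccnc3c(-c3ccc4ncn(C5CCCCC5)c4c3)n2)cc1` gives 6.3%, and compound 2 `Fc1ccccc1-c1cn2ccnc2c(-c2ccc3ncn(C4CCCCC4)c3c2)n1` gives 4.51%. For the measured compounds named here, the one single-point change among the measured compounds, 2-fluorophenyl in place of 4-chlorophenyl on an aromatic carbon, gives a number 1.8 percentage points lower from compound 1 to compound 2 (within the scatter). Compound 3 `c1cn2cc(-c3ccc4c(c3)ncn4C3CCCCC3)nc(-c3ccc4ncn(C5CCCCC5)c4c3)c2n1` gives 35.7% and stands highest of the three, with gaps to compound 1 and compound 2 that both lie beyond the scatter, so its inhibition in this assay is the highest measured so far.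

Compound 4 `c1ccc(Cn2cnc3ccc(-c4nc(-c5ccc6c(c5)ncn6C5CCCCC5)cn5ccnc45)cc32)cc1` has not yet been measured. It differs from compound 3 in one place: benzyl in place of cyclohexyl on an aromatic nitrogen. Going by the values given here, no measured step touches a group on the aromatic nitrogen; the only known step concerns a group on an aromatic carbon and stayed within the scatter, so it gives no guide to direction or size here. With nothing to push the number up or down, compound 4 is estimated at 30%, with a range from 10% to 55%. That estimate means an expected step of a number 5.7 percentage points lower from compound 3 to compound 4 (within the scatter), which is expected to stay within the scatter.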

Compound 4, a percentage reported as inhibition, at one concentration (the size of the read-out at that concentration, not a potency): -77.6%
For compound 4 the middle estimate is 107.6 percentage points above the measured one; the measured number lies below the stated range.
By their numbers in this assay, from the lowest: compound 4; then compounds 2 and 1 (each within the scatter of the next); then compound 3.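

In this assay, the change on this aromatic nitrogen gives a number 113.3 percentage points lower from compound 3 to compound 4 (beyond the scatter), the first step among these compounds to lie beyond the scatter, and compound 4 at -77.6% sits below zero on a read-out of inhibition. The group on this nitrogen therefore matters greatly here, even though cyclohexyl and benzyl are both six-membered rings of carbon at heart, with no hydrogen-bond donors or acceptors and no net charge on either. For the compounds shown here, nothing available explains why this swap moves the number so far.

A cyclohexylmethyl group on the same nitrogen would help show whether the aromatic ring or the extra carbon carries the change. From the compounds shown here alone, how a small methyl or a chain ending in an amine would read at this position remains open.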